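A few compounds are considered here, and "the series" means these few. Any claim that something is new, unique, unknown or untested is made for them only; others in the source may bear on it.

Compound 3, with the structure `CSc1cnc2ccccc2c1[Se]CC#CCOC(=O)c1ccccc1`, is the reference point for this step. Among the measured compounds shown here, in a functional assay on CCRF-CEM cells (Homo sapiens) for antiproliferative activity, with a stated time of 72 h (a lower number here means a stronger inhibitor, a higher number a weaker inhibitor), compound 3 gives 1.9 ug/mL, which places it second highest of the three numbers measured so far. Compound 1, `CSc1cnc2ccccc2c1[Se]CC#CCOC(=O)c1ccc(C(=O)O)cc1`, gives 4 ug/mL in this assay, and compound 2, `CSc1cnc2ccccc2c1[Se]CC#CCO`, gives 0.5 ug/mL. The two measured steps both end at compound 3: the change of hydrogen in place of carboxy on an aromatic carbon gave a 2.1-fold lower number from compound 1 to compound 3 (0.32 log units; beyond the scatter), and the change of benzoyl in place of hydrogen on an oxygen on a saturated carbon gave a 3.8-fold higher number from compound 2 to compound 3 (0.58 log units; beyond the scatter).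

Compound 4, `CSc1cnc2ccccc2c1[Se]CC#CCOC(=O)/C=C/c1ccccc1`, differs from compound 3 in one place: 2-phenylethenyl in place of phenyl on a carbonyl carbon. Both measured steps bear on this only loosely, since each altered the ester end of the chain and each moved the number by a modest amount. Neither step probes a 2-phenylethenyl group, so a large shift is not anticipated; a modest rise in the number, of the order seen from compound 2 to compound 3, is the nearest analogy. Compound 4 is therefore expected to give roughly 2.2 ug/mL in this assay, within a range of 1 ug/mL to 4.8 ug/mL, the estimated step being a 1.2-fold higher number from compound 3 to compound 4 (0.06 log units; within the scatter).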

Compound 4, concentration for 50% inhibition: 17.8 ug/mL
Estimate against measurement, compound 4: 8.1-fold (0.91 log units) below; measured number outside the range, above it.
By their numbers in this assay, from the lowest: compound 2; then compound 3; then compound 1; then compound 4.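

In this assay, among the compounds shown here, the group on the carbonyl carbon turns out to matter much more than the earlier compounds indicated: 2-phenylethenyl in place of phenyl gave a 9.4-fold higher number from compound 3 to compound 4 (0.97 log units; beyond the scatter), a larger step than either a 3.8-fold higher number from compound 2 to compound 3 (0.58 log units; beyond the scatter) or a 2.1-fold lower number from compound 1 to compound 3 (0.32 log units; beyond the scatter). The change from 4-carboxyphenyl to 2-phenylethenyl at the same place gave a 4.5-fold higher number from compound 1 to compound 4 (0.65 log units; beyond the scatter), so the ester carrying the carboxy group, which had the higher number of the two benzoate-type esters, no longer marks the upper end of this short series. Nothing among the data shown accounts for this rise.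

The compounds shown do not separate the double bond from the greater length of the group, and a saturated 2-phenylethyl group at the same carbonyl carbon would be the direct test of which of the two goes with the higher number. They also leave open whether a carboxylic acid or a methoxy group on the ring of the 2-phenylethenyl group would shift the number in the way the carboxy group did on the phenyl ring of the benzoate.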